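Anilino variation on the shared core: compound 3 to compound 4

The source may report more compounds than this note shows. Statements on the series, on what has been measured and on what is new or still open speak of the compounds shown alone.

Measured so far:
compound 1 `Cc1n[nH]c2ccc(-c3nc4cnc(N5CCN(C)CC5)cn4c3Nc3ccc(Cl)cc3)cc12` — 8.11%
compound 2 `Cc1n[nH]c2ccc(-c3nc4cnc(N5CCN(C)CC5)cn4c3Nc3ccc(I)cc3)cc12` — "not determined" (no result reported)
compound 3 `Cc1cc(Br)ccc1Nc1c(-c2ccc3[nH]nc(C)c3c2)nc2cnc(N3CCN(C)CC3)cn12` — "not determined" (no result reported)

Within the data shown here, in a functional assay on CWR22R cells (Homo sapiens) for inhibition, with a stated time of 120 h, tested at 10 uM (a higher number here means more inhibition at the concentration tested (going by the name of the read-out), a lower number less inhibition), compound 1 gives 8.11%, and this is the only number. In this assay compound 2 gives "not determined" (no result reported) and compound 3 gives "not determined" (no result reported), so compound 3 cannot be placed against compound 1 or compound 2 on the numbers; it stands without a value, and one further entry is likewise without a number.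

Compound 4 `Cc1n[nH]c2ccc(-c3nc4cnc(N5CCN(C)CC5)cn4c3Nc3ccc(F)cc3Br)cc12` is the next compound to be measured in this assay. The change from compound 3 is 2-bromo-4-fluorophenyl in place of 4-bromo-2-methylphenyl on a nitrogen on an aromatic ring. Among the measured compounds shown here, no step between measured compounds exists in this assay, so there is no measured step to compare it with. For the measured compounds named here, the expected step in this assay from compound 3 to compound 4 cannot be stated as a number; what can be said is that the only measured member, compound 1, shows little inhibition, and the whole series is expected to stay in that region.

Compound 4 is estimated to give 10% in this assay, within 0% to 30%, because compound 1 gives 8.11% and the two share the whole core.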

Compound 4, a percentage reported as inhibition, at one concentration (the size of the read-out at that concentration, not a potency): 4.41%
Beside the measured number, compound 4's estimate is 5.6 percentage points above it; low and high end bracket the measured number.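

In this assay, the series now has its first readable step at the aryl group on a nitrogen on an aromatic ring: a number 3.7 percentage points lower from compound 1 to compound 4 (within the scatter), with 2-bromo-4-fluorophenyl in place of 4-chlorophenyl, so this exchange of halogen-bearing phenyl groups does not separate the two compounds at the single concentration tested. The step from compound 3 cannot be read, as compound 3 has no reported result, and the exchange of 4-bromo-2-methylphenyl for 2-bromo-4-fluorophenyl therefore says nothing on its own. No measurement at hand accounts for the read-out at this position.

The compounds shown carry only halogen or methyl groups on this phenyl ring, so it remains open whether an amine or a carboxylic acid there, or a longer chain on the same nitrogen in place of the phenyl ring, would lift inhibition clear of the level of compound 1 and compound 4. With the rest of the shared core identical in all of them, the compounds also leave open whether any change away from this nitrogen would alter the read-out.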